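The source may hold more compounds than are shown below. What is called first, only, known or untested is meant among the compounds shown, and "the series" means these compounds.

Measured so far in a functional assay (brain) for inhibition, with Rattus norvegicus as the target; a higher number here means a weaker inhibitor, a lower number a stronger inhibitor
compound 1 `CCCCCCCCCCOC1=C(O)OC(C(O)CO)C1=O` gives 13000 nM
compound 2 `CCCCCCCCCCCCCCCCOC1=C(O)OC(C(O)CO)C1=O` gives 6800 nM

Compound 2 holds the lower of the two numbers, but its gap to compound 1 lies within the scatter. Compound 3 `CCCCCCCCCCCCCCCCCOC1=C(O)OC(C(O)CO)C1=O` differs from compound 2 by methyl in place of hydrogen on a saturated chain carbon, ten or more bonds along the chain from an oxygen on an unsaturated carbon and so carries methyl in place of hydrogen on a saturated chain carbon. Among the compounds with values here, the one measured step bearing on this is a 1.9-fold lower number from compound 1 to compound 2 (0.28 log units; within the scatter) for hexyl in place of hydrogen on such a carbon. Methyl is the smaller addition, so no step beyond the scatter is expected in this assay in either direction. The estimated step is a 1.0-fold lower number from compound 2 to compound 3 (0.02 log units; within the scatter) and is expected to stay within the scatter. Compound 3 is expected at 6500 nM with an estimated range from 3000 nM to 14000 nM for the coming measurement.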

Compound 3, half-maximal inhibitory concentration: 11000 nM
The estimate for compound 3 lay 1.7-fold (0.23 log units) below the measured number, and the stated range covers the measured number.
By their numbers in this assay, from the lowest: compounds 2, 3 and 1 (each within the scatter of the next).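

The added methyl on the saturated chain gives a 1.6-fold higher number from compound 2 to compound 3 (0.21 log units; within the scatter) in this assay. Heptyl in place of hydrogen on that chain gives a 1.2-fold lower number from compound 1 to compound 3 (0.07 log units; within the scatter), so all three chains now sit within the scatter of each other and no order among them can be read. Nothing measured here offers an explanation for this result.

Open, going by these compounds, is whether a longer chain, or an amine or a carboxylic acid on the chain, would move the number beyond the scatter.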